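The compounds below may be only part of what the source reports. "The series", "measured", "known", "first", "only" and "open" are said of these compounds alone.

Three compounds of this series have been run in a functional assay on MGC-803 cells (Homo sapiens) for inhibition, read by MTT assay, with a stated time of 72 h; a lower number here means a stronger inhibitor, a higher number a weaker inhibitor. Compound 1 `Cc1cc(N2CC[C@@H](C)[C@@H](N(C)c3ncnc4[nH]ccc34)C2)n2nc(SCc3cc(Cl)ccc3Cl)nc2n1` gives 9850 nM. Compound 2 `C=CCSc1nc2nc(C)cc(N3CC[C@@H](C)[C@@H](N(C)c4ncnc5[nH]ccc45)C3)n2n1` gives 32600 nM. Compound 3 `C#CSc1nc2nc(C)cc(N3CC[C@@H](C)[C@@H](N(C)c4ncnc5[nH]ccc45)C3)n2n1` gives 18100 nM. Compound 2 holds the highest of the three numbers; its nearest neighbour is compound 3, with a 1.8-fold lower number from compound 2 to compound 3 (0.26 log units; within the scatter), and its furthest is compound 1, with a 3.3-fold higher number from compound 1 to compound 2 (0.52 log units; beyond the scatter). Between the other two the step is a 1.8-fold higher number from compound 1 to compound 3 (0.26 log units; within the scatter).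

The next compound, compound 4 `COc1ccc(CSc2nc3nc(C)cc(N4CC[C@@H](C)[C@@H](N(C)c5ncnc6[nH]ccc56)C4)n3n2)cc1`, differs from compound 2 at one place: 4-methoxyphenyl in place of vinyl on a saturated chain carbon bound to a sulfur. Among the compounds with values here, the only measured step that bears on this exchange is the one from compound 1 to compound 2, where a 2,5-dichlorophenyl on the saturated chain carbon bound to a sulfur gave way to vinyl, a 3.3-fold higher number from compound 1 to compound 2 (0.52 log units; beyond the scatter); read in reverse, putting a substituted phenyl back onto that carbon went with a lower number. The two steps involving compound 3 remain within the scatter and add little. Within the data shown here, no measured pair sets 4-methoxyphenyl against 2,5-dichlorophenyl, so the size of the step is open. Compound 4 is expected to give about 14000 nM in this assay, with a range from 6000 nM to 33000 nM. That expectation corresponds to a step of a 2.3-fold lower number from compound 2 to compound 4 (0.37 log units; beyond the scatter), toward a lower number.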

Compound 4, half-maximal inhibitory concentration: 15200 nM
Estimate against measurement, compound 4: 1.1-fold (0.04 log units) below; low and high end bracket the measured number.
By their numbers in this assay, from the lowest: compounds 1, 4, 3 and 2 (each within the scatter of the next, the first and the last beyond it).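

In this assay, 4-methoxyphenyl in place of vinyl on the saturated chain carbon bound to a sulfur gives a step beyond the scatter (a 2.1-fold lower number from compound 2 to compound 4 (0.33 log units; beyond the scatter)), so a second substituted phenyl now goes with a lower number than vinyl at this place, and the earlier result no longer rests on 2,5-dichlorophenyl alone. The two substituted phenyl groups cannot be told apart (a 1.5-fold higher number from compound 1 to compound 4 (0.19 log units; within the scatter)), and compound 3, which carries ethynyl on the sulfur and no ring, goes against any simple need for a phenyl group, since it also cannot be told apart from compound 4 (a 1.2-fold lower number from compound 3 to compound 4 (0.08 log units; within the scatter)). Nothing at hand accounts for the difference between vinyl and the substituted phenyl groups.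

On these data alone, it remains open whether unsubstituted phenyl, a pyridine ring, or an amine or carboxylic acid carried on the phenyl ring would separate from the two substituted phenyl groups seen so far. As far as these compounds go, it is equally open whether a longer alkyl chain on the sulfur would behave like allyl, and whether any change here can bring the number well under that of compound 1 (9850 nM).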